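Anomeric configuration change on the glycoside of compound 2

This account rests on a few compounds, and the source may have more. Where it says the series, first, only, none or still open, it means among the compounds named here.

Measured so far in a functional assay on MDA-MB-231 cells (Homo sapiens) for cytotoxicity, read by MTT assay, with a stated time of 48 h; on this read-out lower numbers stand for an effect already at smaller amounts and higher numbers for an effect only at larger amounts of compound:
- compound 2 `CO[C@H]1O[C@H](COc2ccccc2C(C)C)[C@@H](O)[C@H](O)[C@H]1Oc1ccc(OC2CCCCC2)cc1`: 36000 nM
- compound 3 `CO[C@H]1O[C@H](COc2ccc(C3CCCCC3)cc2)[C@@H](O)[C@H](O)[C@H]1Oc1ccc(OC2CCCCC2)cc1`: 14000 nM
- compound 1 `CO[C@@H]1O[C@H](COc2ccc3c(c2)CCCC3)[C@@H](O)[C@H](O)[C@H]1Oc1ccc(OC2CCCCC2)cc1`: "not determined" (no result reported)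

Going by the values given here, compound 2 gives the highest of the two numbers available in this assay; its nearest neighbour is compound 3, and the single one-place step seen so far, a 2.6-fold lower number from compound 2 to compound 3 (0.41 log units; beyond the scatter), concerns the aryl group on the oxygen on the saturated carbon. Compound 1 carries a different aryl group at that same oxygen and the other configuration at the ring stereocentre, but no number exists for it.

Compound 4 `CO[C@@H]1O[C@H](COc2ccccc2C(C)C)[C@@H](O)[C@H](O)[C@H]1Oc1ccc(OC2CCCCC2)cc1` is the partner of compound 2 in which (the two compounds have the same atoms and bonds and differ only in configuration as drawn: 1 of 5 stereo elements differ; a stereocentre at a saturated ring carbon is drawn S in compound 2 and R in compound 4). Among the compounds with values here, no measured step bears on this kind of change: the only step in hand, from compound 2 to compound 3, alters a substituent, not a stereocentre, and compound 1 gives nothing to compare. The aryl groups and the rest of the core are unchanged, so without evidence either way the expectation is a step of no size beyond the scatter, no change at the digits printed from compound 2 to compound 4 (within the scatter).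

Compound 4 is therefore expected to give about 36000 nM in this assay, within a range of 14000 nM to 90000 nM.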

Compound 4, half-maximal effective concentration: 44000 nM
For compound 4 the middle estimate is 1.2-fold (0.09 log units) below the measured one; the range from low to high includes it.
By their numbers in this assay, from the lowest: compound 3; then compounds 2 and 4 (each within the scatter of the next).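

Inverting the stereocentre at a saturated ring carbon, from S to R, gives a 1.2-fold higher number from compound 2 to compound 4 (0.09 log units; within the scatter) in this assay, the first reading on configuration in this series. The comparison isolates a single feature: the fact that compounds 2 and 4 differ only in the configuration as drawn. Going by these compounds alone, with the 2-isopropylphenyl group in place, configuration at this stereocentre does not separate the two compounds in this assay, whereas the only step beyond the scatter so far, a 2.6-fold lower number from compound 2 to compound 3 (0.41 log units; beyond the scatter), is a change of aryl group on the oxygen on the saturated carbon.

The compounds shown include no pair with two numbers that tests this inversion with 4-cyclohexylphenyl in place of 2-isopropylphenyl, so it remains open whether the stereocentre is equally silent with another aryl group. Also open, from the compounds shown here alone, is how the S and R forms compare when that aryl group carries an amine or a carboxylic acid.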